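Moving a Methyl Group on a Dichlorophenyl Series

The source may hold more compounds than are shown below. What is called first, only, known or untested is meant among the compounds shown, and "the series" means these compounds.

Values so far in a functional assay on HL-60 cells (Homo sapiens) for cytotoxicity, read by WST assay, with a stated time of 48 h; a lower number here means that less compound is needed, a higher number that more compound is needed for the effect
- Compound 1 (`COCOc1ccc(C[C@H]2C(=O)OC[C@@H]2Cc2ccccc2)cc1`) gives (71000 nM)
- Compound 2 (`CCOc1ccccc1C[C@H]1COC(=O)[C@@H]1Cc1ccc(Cl)c(Cl)c1`) gives (15000 nM)
- Compound 3 (`Cc1ccccc1C[C@H]1COC(=O)[C@@H]1Cc1ccc(Cl)c(Cl)c1`) gives (22000 nM)

Compound 1 (71000 nM) carries a higher number than compound 3 (22000 nM), and compound 3 lies within the scatter of compound 2. Compound 4 (`Cc1ccc(C[C@H]2COC(=O)[C@@H]2Cc2ccc(Cl)c(Cl)c2)cc1`) has not yet been measured. It has the same atoms as compound 3, joined differently (4-methylphenyl in place of 2-methylphenyl on a saturated chain carbon bound to a saturated ring carbon). Among the measured compounds shown here, no measured step shows this exact change. The closest evidence is a change of methyl in place of ethoxy on an aromatic carbon (a 1.5-fold higher number from compound 2 to compound 3 (0.17 log units; within the scatter)). That single step stays within the scatter, so a shift beyond the scatter is not expected in this assay, and no direction can be favoured. One step is thin evidence, so the range is kept wide. The estimated step is (a 1.1-fold lower number from compound 3 to compound 4 (0.04 log units; within the scatter)). For compound 4 the estimated value is (20000 nM), with an expected range from (9000 nM) to (45000 nM).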

Compound 4, half-maximal effective concentration: 19000 nM
Beside the measured number, compound 4's estimate is 1.1-fold (0.02 log units) above it; measured number inside the range.
By their numbers in this assay, from the lowest: compounds 2, 4 and 3 (each within the scatter of the next); then compound 1.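

In this assay, among the compounds shown here, the change a 1.2-fold lower number from compound 3 to compound 4 (0.06 log units; within the scatter) is the first that keeps the same atoms and alters only how they are joined, with 4-methylphenyl in place of 2-methylphenyl on a saturated chain carbon bound to a saturated ring carbon. The earlier step, a 1.5-fold higher number from compound 2 to compound 3 (0.17 log units; within the scatter), exchanged one group for another, whereas this one shows that the assay does not tell these two placements of the methyl group apart. No accompanying measurement bears on this result, so nothing here accounts for it.

The compounds shown leave open whether an amine or a carboxylic acid in place of the methyl group would move the number beyond the scatter. They also leave open what a longer chain at that same spot would do in this assay.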